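Swapping a Pyridine Arm for a Fluorobenzyl Arm

The compounds below may be only part of what the source reports. "The series", "measured", "known", "first", "only" and "open" are said of these compounds alone.

Compound 1 `Cn1c(Cc2ccccc2C(F)(F)F)nc(C(=O)NCc2ccccn2)c(O)c1=O` shows no measurable effect in an ADME assay on HepG2 cells (Homo sapiens) for cytotoxicity, in the presence of a further agent that is not named here; on this read-out lower numbers stand for stronger inhibition and higher numbers for weaker inhibition: compound 1 gives > 100000 nM, which is a limit of the test rather than a number. For the measured compounds named here, compound 2 `O=C(NCc1ccccc1)c1nc(Cc2ccccc2C(F)(F)F)[nH]c(=O)c1O` is the only other compound measured, and in this assay compound 2 gives > 100000 nM, again a limit. Both results sit at the limit of > 100000 nM in this assay, at which 2 of the 2 values shown sit, so compound 1 stands only at a limit, with no number to rank it. Compound 3 `Cn1c(Cc2ccccc2C(F)(F)F)nc(C(=O)NCc2ccccc2F)c(O)c1=O` differs from compound 1 by 2-fluorophenyl in place of pyridin-2-yl on a saturated chain carbon bound to an amide-type nitrogen. Going by the values given here, with no measured step to draw on, the step expected from compound 1 to compound 3 is a step that the limit leaves unreadable from compound 1 to compound 3, nothing beyond the scatter. Compound 3 is therefore expected to give about 150000 nM, between 50000 nM and 500000 nM, most likely once more only a limit.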

Compound 3, half-maximal inhibitory concentration: > 100000 nM
Compound 3 was reported as a limit; the forecaster's own chance of this, stated with the estimate: 85%; the middle value is on the limit's open side.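

For the compounds shown here, compound 3, like compound 1, stands only at a limit in this assay, so no step between them can be read: the limit of > 100000 nM in this assay, at which 3 of the 3 values shown sit. The compounds shown leave open whether pyridin-2-yl and 2-fluorophenyl differ at all in this assay.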